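Oxazole ketone series: the aryl group on the core

This account rests on a few compounds, and the source may have more. Where it says the series, first, only, none or still open, it means among the compounds named here.

Measured so far:
- compound 1, `Nc1cccc(-c2cnc(C(=O)CCCCCCc3ccccc3)o2)c1`: in an assay (Rattus norvegicus) for inhibition of Fatty-acid amide hydrolase 1 (Homo sapiens) (on this read-out lower numbers stand for stronger inhibition and higher numbers for weaker inhibition), compound 1 gives 19 nM
- compound 2, `O=C(CCCCCCc1ccccc1)c1ncc(-c2ccc([N+](=O)[O-])cc2)o1`: compound 2 gives 50 nM
- compound 3, `Cc1ccc(-c2cnc(C(=O)CCCCCCc3ccccc3)o2)nc1`: compound 3 gives 2.8 nM

Compound 3 stands lowest of the three numbers, the steps to both others lying beyond the scatter: a 6.8-fold lower number from compound 1 to compound 3 (0.83 log units; beyond the scatter) and an 18-fold lower number from compound 2 to compound 3 (1.25 log units; beyond the scatter). Between the two phenyl-bearing compounds the gap is smaller: a 2.6-fold higher number from compound 1 to compound 2 (0.42 log units; beyond the scatter). All three steps swap the whole aryl group on the shared core, so this position is clearly sensitive, but none of them changes one ring atom or removes one methyl while keeping the ring type.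

Compound 4, `O=C(CCCCCCc1ccccc1)c1ncc(-c2ncccn2)o1`, carries pyrimidin-2-yl in place of 5-methylpyridin-2-yl on an aromatic carbon. For the measured compounds named here, no measured step bears directly on this change; the measured steps only show that aryl swaps here move the number by modest to large amounts. Given that compound 3 gives 2.8 nM and the change is smaller than any measured swap, a modest rise is expected: a 2.5-fold higher number from compound 3 to compound 4 (0.40 log units; beyond the scatter). Compound 4 is estimated at 7 nM, within 2 nM to 25 nM.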

Compound 4, inhibition constant: 5.3 nM
For compound 4 the middle estimate is 1.3-fold (0.12 log units) above the measured one; the measured number falls inside the stated range.
By their numbers in this assay, from the lowest: compounds 3 and 4 (each within the scatter of the next); then compound 1; then compound 2.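

In this assay, exchanging 5-methylpyridin-2-yl for pyrimidin-2-yl gives no separable change: a 1.9-fold higher number from compound 3 to compound 4 (0.28 log units; within the scatter). Compound 3 therefore no longer stands alone at the low end, since the pyrimidin-2-yl group also lies clear of both phenyl-bearing compounds, with a 9.4-fold lower number from compound 2 to compound 4 (0.97 log units; beyond the scatter) and a 3.6-fold lower number from compound 1 to compound 4 (0.55 log units; beyond the scatter), and among these four compounds both groups carrying ring nitrogen give lower numbers than both substituted phenyl groups. No supporting data bear on the reason for these steps.

The step from compound 3 to compound 4 removes the methyl and adds a second ring nitrogen together, so the share of each remains unresolved. An unsubstituted pyridin-2-yl group would separate the two, and an unsubstituted phenyl group would show what the ring nitrogen contributes at this position.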